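This account rests on a few compounds, and the source may have more. Where it says the series, first, only, none or still open, it means among the compounds named here.

Among the compounds with values here, compound 3 `COc1ccc(/C=C2\CCC/C(=C\c3ccccc3Cl)C2=O)cc1OC` gives the highest of the three numbers so far in an ADME assay on NHDF cells (Homo sapiens) for cytotoxicity, read by MTT assay, with a stated time of 72 h (a higher number here means a weaker inhibitor, a lower number a stronger inhibitor), with 21600 nM, though its neighbours sit within the scatter: compound 1 `COc1cccc(/C=C2\CCC/C(=C\c3cccc(Cl)c3)C2=O)c1OC` gives 21400 nM in this assay, and compound 2 `COc1cccc(/C=C2\CCC/C(=C\c3cccc(O)c3)C2=O)c1OC` gives 19300 nM. Within the data shown here, the one measured step, a 1.1-fold lower number from compound 1 to compound 2 (0.04 log units; within the scatter), shows that exchanging hydroxy for chloro on the aromatic ring left the cytotoxicity unchanged beyond the scatter. Compound 4 `COc1ccc(/C=C2\CCC/C(=C\c3ccc(Cl)cc3Cl)C2=O)cc1OC` differs from compound 3 by one change: chloro in place of hydrogen on an aromatic carbon. Among the measured compounds shown here, no measured step adds a chloro to an already chlorinated ring, so the step from compound 1 to compound 2 bears on it only loosely, as a sign that substituent changes on this ring have so far moved this assay little. On that basis, compound 4 is expected to show essentially no step beyond the scatter, with an estimated 1.0-fold lower number from compound 3 to compound 4 (0.01 log units; within the scatter). The estimate for compound 4 in this assay is therefore 21000 nM, with a range from 11000 nM to 40000 nM.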

Compound 4, half-maximal inhibitory concentration: > 50000 nM
Compound 4 was reported as a limit; the forecaster's own chance of this, stated with the estimate: 10%; middle value at least 2.3-fold (0.37 log units) away from the limit.
By their numbers in this assay, from the lowest: compounds 2, 1 and 3 (each within the scatter of the next). At a limit, above all of these: compound 4.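

Chloro in place of hydrogen, para to a large group and meta to a chloro group, gives an at least 2.3-fold higher number from compound 3 to compound 4 (0.36 log units; beyond the scatter) in this assay. Unlike the earlier exchange of hydroxy for chloro, a 1.1-fold lower number from compound 1 to compound 2 (0.04 log units; within the scatter), this change turning 2-chlorophenyl into 2,4-dichlorophenyl moves the number beyond the scatter, so this place on the ring is not as silent as the earlier compounds suggested. Compound 4 is the only compound shown that stands at a limit, so the step has a lower bound and no fixed size: the limit of > 50000 nM in this assay, at which 1 of the 4 values shown sits.

The compounds shown leave open whether another group at this place, such as an amine or a carboxylic acid, would give a similar step. They also leave open whether the same added chloro would have such an effect on the core of compound 1.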